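Methyl on the ring nitrogen of compound 2

The compounds below may be only part of what the source reports. "The series", "measured", "known", "first", "only" and "open" are said of these compounds alone.

Compound 1 `Cn1c(SCC(=O)N2CCC[C@H]2C(=O)Nc2ccccc2-n2cccc2)nc2ccccc21`: 9 nM
Compound 2 `Cc1ccc2[nH]c(SCC(=O)N3CCC[C@H]3C(=O)Nc3ccccc3-n3cccc3)nc2c1`: 3 nM
Compound 3 `O=C(Nc1ccccc1-c1ccccc1)[C@@H]1CCCN1C(=O)CSc1nc2ccccc2[nH]1`: 10 nM

In an assay on CHO cells for displacement of a labelled ligand from Orexin/Hypocretin receptor type 1 (Homo sapiens) (a higher number here means a weaker inhibitor, a lower number a stronger inhibitor), compound 2 gives the lowest of the three numbers; compound 1 and compound 3 both sit above it, each by a step beyond the scatter. Compound 4 `Cc1ccc2c(c1)nc(SCC(=O)N1CCC[C@H]1C(=O)Nc1ccccc1-n1cccc1)n2C` differs from compound 2 by methyl in place of hydrogen on an aromatic nitrogen. For the measured compounds named here, no measured step isolates this change. Going by the values given here, the only step touching the ring nitrogen, a 3.0-fold lower number from compound 1 to compound 2 (0.48 log units; beyond the scatter), also moves a methyl onto the fused ring, so it cannot be read as the effect of methylation alone. Compound 3 carries no methyl anywhere and gives 10 nM. The expectation for compound 4 is therefore a small step, if any, toward a higher number, a 1.7-fold higher number from compound 2 to compound 4 (0.22 log units; within the scatter). Compound 4 is estimated at 5 nM, between 2 nM and 15 nM.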

Compound 4, inhibition constant: 0.7 nM
Beside the measured number, compound 4's estimate is 7.1-fold (0.85 log units) above it; the whole stated range lies above it.
By their numbers in this assay, from the lowest: compound 4; then compound 2; then compounds 1 and 3 (each within the scatter of the next).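

In this assay, the aromatic nitrogen need not keep its hydrogen: methyl there gives a 4.3-fold lower number from compound 2 to compound 4 (0.63 log units; beyond the scatter). The methyl on the aromatic carbon also matters with the nitrogen methyl in place, giving a 13-fold lower number from compound 1 to compound 4 (1.11 log units; beyond the scatter). Together these steps separate the two methyl positions, which the earlier shift of one methyl could not do, and no evidence is at hand to explain either step. From the compounds shown here alone, whether ethyl or a longer chain on that nitrogen would keep the number this low stays open.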